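Removing the propylsulfonyl from compound 1

The compounds below may be only part of what the source reports. "The series", "measured", "known", "first", "only" and "open" are said of these compounds alone.

Compound 1 `CCCS(=O)(=O)Nc1cccc2c1CCCC2c1c[nH]cn1` was examined in an assay on isolated protein for binding affinity to Alpha-1D adrenergic receptor (Rattus norvegicus), read by radioligand binding; a lower number here means a stronger inhibitor, a higher number a weaker inhibitor. For compound 1 the readout is a limit of the assay, < 10000 nM, rather than a number (the limit of < 10000 nM in this assay, at which 1 of the 3 values shown sits). Two related compounds carry numbers: compound 2 `CCS(=O)(=O)Nc1cc(F)cc2c1CCCC2c1c[nH]cn1` gives 3630 nM in this assay, and compound 3 `CCS(=O)(=O)Nc1cccc2c1CCC2c1c[nH]cn1` gives 977 nM. Compound 4 `Nc1cccc2c1CCCC2c1c[nH]cn1` has not yet been measured. It differs from compound 1 by hydrogen in place of propylsulfonyl on a nitrogen on an aromatic ring. Among the compounds with values here, no measured pair in this set shows the effect of this change, so the direction of the step cannot be read from the data. The step that the limit leaves unreadable from compound 1 to compound 4 is expected to be small and of uncertain direction. Compound 4 is therefore estimated at 4000 nM, with a range from 600 nM to 25000 nM.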

Compound 4, inhibition constant: 191 nM
Estimate against measurement, compound 4: 21-fold (1.32 log units) above, outside the stated range (below it).
By their numbers in this assay, from the lowest: compound 4; then compound 3; then compound 2.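

No step can be read between compound 1 and compound 4, because the value of compound 1 is a limit and not a number: the limit of < 10000 nM in this assay, at which 1 of the 4 values shown sits.

The compounds shown leave open the size and direction of the change from propylsulfonyl to hydrogen.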